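A few compounds are considered here, and "the series" means these few. Any claim that something is new, unique, unknown or untested is made for them only; others in the source may bear on it.

Three analogues sharing one core have been tested in an ADME assay on HFF cells (Homo sapiens) for cytotoxicity, with a stated time of 8 days; on this read-out higher numbers stand for lower toxicity in this test and lower numbers for higher toxicity in this test. Compound 1 `CCCCSc1nc(N)nc2c1ncn2/C=C1/CC1(CO)CO` carries a butylsulfanyl group; in this assay compound 1 reaches only the limit > 300000 nM. Compound 2 `CC(C)CNc1nc(N)nc2c1ncn2/C=C1/CC1(CO)CO` carries an isobutylamino group in its place, and compound 2 likewise gives the limit > 300000 nM. Compound 3 `CCCCNc1nc(N)nc2c1ncn2/C=C1/CC1(CO)CO` carries a butylamino group, and compound 3 stops at the same limit > 300000 nM. Because all three sit at the limit of > 300000 nM in this assay, at which 3 of the 3 values shown sit, none of the pairwise steps can be sized: a step that the two limits leave unreadable from compound 1 to compound 2, a step that the two limits leave unreadable from compound 1 to compound 3 and a step that the two limits leave unreadable from compound 2 to compound 3 all remain unreadable. Compound 3 therefore stands at the limit alongside its two companions, with no number to distinguish it.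

Compound 4 `COCCOc1nc(N)nc2c1ncn2/C=C1/CC1(CO)CO` is the next member. It differs from compound 3 in one place: 2-methoxyethoxy in place of butylamino on an aromatic carbon. For the measured compounds named here, no measured step bears directly on this change, and the steps that exist are unreadable, so the only guide is that every measured compound sits at the limit. On that basis compound 4 is expected to show little or no toxicity in this assay, with an estimate of 400000 nM in the range 150000 nM to 1000000 nM, so that the expected step that the limit leaves unreadable from compound 3 to compound 4 lies within the scatter and most likely ends again at the limit.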

Compound 4, half-maximal cytotoxic concentration: > 300000 nM
Compound 4 was reported as a limit; the forecaster's own chance of this, stated with the estimate: 85%; the middle value does not contradict the limit.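

In this assay compound 4 gives > 300000 nM, which is a limit. The steps to compound 4 from compound 1, compound 2 and compound 3 cannot be read, as all four compounds stand at one limit: the limit of > 300000 nM in this assay, at which 4 of the 4 values shown sit.

The compounds shown leave open whether any group at this place gives a readable half-maximal cytotoxic concentration, and how these four would rank.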